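This account rests on a few compounds, and the source may have more. Where it says the series, first, only, none or still open, it means among the compounds named here.

Working notes on the series. Compound 1 `Cc1nc2sc(-c3ccc(C(F)(F)F)cc3)nc2c(=O)[nH]1` and compound 2 `Cc1cccc(-c2nc3c(=O)[nH]c(C)nc3s2)c1` share one core and differ only in the substituent on the six-membered aromatic ring of carbon only. In an assay on CHO cells for displacement of a labelled ligand from adenosine receptor A1 (Homo sapiens), read by scintillation counting, with a stated time of 120 min, tested at 1 uM (a higher number here means more inhibition at the concentration tested (going by the name of the read-out), a lower number less inhibition), compound 1 gives 1%. In this assay compound 2 gives 1%, level with compound 1 at the digits shown; the two values lie within the scatter of repeated measurements, so no order between them can be claimed.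

Compound 3 `Cc1nc2sc(-c3cccc(C(F)(F)F)c3)nc2c(=O)[nH]1` differs from compound 2 by trifluoromethyl in place of methyl on an aromatic carbon, the change sitting on an aromatic carbon of a six-membered aromatic ring of carbon only, meta to a large group. Going by the values given here, no step between measured compounds exists here. Compound 1 already carries a trifluoromethyl on that ring and gives 1%, and compound 2 gives 1%. On that basis the step of a number 1 percentage points higher from compound 2 to compound 3 (within the scatter) is expected to be none beyond the scatter. Compound 3 is estimated at 2% in this assay, with a range from -8% to 12%.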

Compound 3, a percentage reported as inhibition, at one concentration (the size of the read-out at that concentration, not a potency): 1%
Beside the measured number, compound 3's estimate is 1 percentage points above it, within the range that was stated.
By their numbers in this assay, from the lowest: compounds 1, 2 and 3 (each within the scatter of the next).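

In this assay, trifluoromethyl in place of methyl on an aromatic carbon, meta to a large group, gives no change at the digits printed from compound 2 to compound 3 (within the scatter), the first step read directly at this position. At the concentration tested, this exchange therefore leaves the read-out where it stood, and compound 3 with 1% remains level with compound 1 at 1%, so the step offers no handle for ordering the three compounds. No separate data bear on this result.

Going by these compounds, whether an amine, a carboxylic acid or a longer chain on this aromatic carbon would move the read-out away from these low values stays open. Also open, on these data alone, is whether any group at this position matters once a compound shows substantial inhibition.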